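Replacing cyano with an oxadiazole on the cyclopropyl ring

The compounds below may be only part of what the source reports. "The series", "measured", "known", "first", "only" and "open" are said of these compounds alone.

In an ADME assay on MDCKII-LE cells (Canis lupus familiaris) for permeability (on this read-out lower numbers stand for lower permeability and higher numbers for higher permeability), compound 1 `N#CCCCCN([C@H](CCC(F)(F)F)C(N)=O)S(=O)(=O)c1ccc(Cl)cc1` gives 24 10^-6 cm/s. Compound 2 `N#CC1(CN([C@H](CCC(F)(F)F)C(N)=O)S(=O)(=O)c2ccc(Cl)cc2)CC1` gives 29.9 10^-6 cm/s, and these two values lie within the scatter of each other. Going by the values given here, the sole measured step, a 1.2-fold higher number from compound 1 to compound 2 (0.10 log units; within the scatter), is 1-cyanocyclopropyl in place of 3-cyanopropyl, a change that keeps the cyano group. Compound 3 `NC(=O)[C@@H](CCC(F)(F)F)N(CC1(c2ncon2)CC1)S(=O)(=O)c1ccc(Cl)cc1` instead loses that group, with 1,2,4-oxadiazol-3-yl in place of cyano on a saturated ring carbon. Among the compounds with values here, no measured pair makes this exchange, so the earlier step bears on it only indirectly, as a change in the same side chain that stayed small. No shift beyond the scatter is therefore expected in this assay, though the data give only weak support for this. The expected change is a 1.4-fold lower number from compound 2 to compound 3 (0.13 log units; within the scatter). For compound 3 the estimated value is 22 10^-6 cm/s, with an expected range of 11 10^-6 cm/s to 38 10^-6 cm/s.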

Compound 3, apparent permeability: 16.4 10^-6 cm/s
Compound 3: the middle estimate sits 1.3-fold (0.13 log units) above what was measured, and the stated range covers the measured number.
By their numbers in this assay, from the lowest: compounds 3, 1 and 2 (each within the scatter of the next).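

In this assay, going by these compounds alone, the earlier compounds all kept the cyano group, whereas the exchange for 1,2,4-oxadiazol-3-yl on this saturated ring carbon gives a 1.8-fold lower number from compound 2 to compound 3 (0.26 log units; within the scatter). The wider change of the side chain gives a 1.5-fold lower number from compound 1 to compound 3 (0.17 log units; within the scatter), so neither the replacement of the cyano group nor the combined change of chain and end group moves the number beyond the scatter. Nothing available explains these small differences.

Going by these compounds, it remains open whether a more strongly charged group on the same ring carbon, such as an amine or a carboxylic acid, would also stay within the scatter. Also open, on these data alone, is whether 1,2,4-oxadiazol-3-yl would behave in the same way at the end of an open chain such as the 3-cyanopropyl chain of compound 1.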